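A New Amide Side Group Tested Against Compound 3

This account rests on a few compounds, and the source may have more. Where it says the series, first, only, none or still open, it means among the compounds named here.

Values in an assay on HEK293 cells for displacement of a labelled ligand from Melanocortin receptor 4 (Homo sapiens); on this read-out higher numbers stand for weaker inhibition and lower numbers for stronger inhibition:
Compound 1 `CC(C)C[C@H](N)c1cc(C(F)(F)F)ccc1N1CCN(C(=O)CNc2ccccc2)CC1`: 3600 nM
Compound 2 `COc1ccc(CC(C)C(=O)N2CCN(c3ccc(C(F)(F)F)cc3[C@@H](N)CC(C)C)CC2)cc1`: 120 nM
Compound 3 `CC(C)C[C@H](N)c1cc(C(F)(F)F)ccc1N1CCN(C(=O)C(C)Cc2ccc(Cl)cc2)CC1`: 47 nM

Compound 3 stands lowest of the three numbers in this assay: a 2.6-fold lower number from compound 2 to compound 3 (0.41 log units; beyond the scatter), and a 77-fold lower number from compound 1 to compound 3 (1.88 log units; beyond the scatter). Compound 4 `CC(C)C[C@H](N)c1cc(C(F)(F)F)ccc1N1CCN(C(=O)COc2ccc([N+](=O)[O-])cc2)CC1` differs from compound 3 in one place: (4-nitrophenoxy)methyl in place of 1-(4-chlorobenzyl)ethyl on a carbonyl carbon. Of the measured steps, a 77-fold lower number from compound 1 to compound 3 (1.88 log units; beyond the scatter) bears most on this change, since compound 1 likewise carries a one-carbon link from the carbonyl carbon to an aromatic ring in that position, and that step was large. The new group is not anilinomethyl, so the reversal need not be full. Compound 4 is therefore expected to give 1200 nM in this assay, with a range of 250 nM to 5000 nM, a step of a 26-fold higher number from compound 3 to compound 4 (1.41 log units; beyond the scatter) toward weaker inhibition.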

Compound 4, inhibition constant: 3100 nM
Beside the measured number, compound 4's estimate is 2.6-fold (0.41 log units) below it; the range from low to high includes it.
By their numbers in this assay, from the lowest: compound 3; then compound 2; then compounds 4 and 1 (each within the scatter of the next).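

In this assay, the ether-linked group and the anilino-linked group cannot be told apart on the one-carbon link from the carbonyl carbon (a 1.2-fold lower number from compound 1 to compound 4 (0.06 log units; within the scatter)). Both of the branched 1-benzylethyl amides hold a large advantage over (4-nitrophenoxy)methyl (a 66-fold higher number from compound 3 to compound 4 (1.82 log units; beyond the scatter); a 26-fold higher number from compound 2 to compound 4 (1.41 log units; beyond the scatter)), so this position tolerates the exchange poorly whichever aromatic substituent is involved. No measurement shown explains these steps.

The compounds shown leave open which part of the exchange carries the loss: the chain, the ether oxygen or the nitro group. A 1-(4-nitrobenzyl)ethyl or a (4-chlorophenoxy)methyl group on the same carbonyl carbon would begin to separate them.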